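Chloro Gives Way to Fluoro: Compound 3 to Compound 4

The compounds below may be only part of what the source reports. "The series", "measured", "known", "first", "only" and "open" are said of these compounds alone.

Compound 3 `COc1ncc(-c2ccn3nc(NC(C)=O)nc3c2)cc1NS(=O)(=O)c1ccc(Cl)cc1` was tested in a functional assay on U-87MG ATCC cells (Homo sapiens) for antiproliferative activity, read by MTT assay, with a stated time of 48 h (on this read-out higher numbers stand for weaker inhibition and lower numbers for stronger inhibition), and gave 2120 nM. Among the three measured compounds it holds the second highest number, close to compound 1 `COc1ncc(-c2ccc3nc(NC(C)=O)nn3c2)cc1NS(=O)(=O)c1ccc(Cl)cc1`, which gave 2090 nM, a gap within the scatter; compound 2 `COc1ncc(-c2ccc3nc(NC(=O)C4CC4)nn3c2)cc1NS(=O)(=O)c1ccc(F)cc1`, which gave 4850 nM, lies further off, beyond the scatter. Compound 4 `COc1ncc(-c2ccn3nc(NC(C)=O)nc3c2)cc1NS(=O)(=O)c1ccc(F)cc1` has not been measured. It differs from compound 3 in one place: fluoro in place of chloro on an aromatic carbon. Among the measured compounds shown here, no measured pair differs by this change alone, so there is no direct precedent. The expected step from compound 3 to compound 4 is small, leaning toward slightly weaker inhibition, a 1.4-fold higher number from compound 3 to compound 4 (0.15 log units; within the scatter). Compound 4 is therefore expected to give about 3000 nM, within a range from 1500 nM to 6500 nM.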

Compound 4, half-maximal inhibitory concentration: 2410 nM
Compound 4: middle estimate off by 1.2-fold (0.10 log units), on the high side; the range from low to high includes it.
By their numbers in this assay, from the lowest: compounds 1, 3, 4 and 2 (each within the scatter of the next, the first and the last beyond it).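

Fluoro in place of chloro on the aromatic carbon, with everything else unchanged, gives a 1.1-fold higher number from compound 3 to compound 4 (0.06 log units; within the scatter) in this assay. Among the compounds shown here, this is the first pair to isolate a single change at this position, and on this read-out the two halogens cannot be told apart here. Nothing measured in this set offers an explanation for this result.

From the compounds shown here alone, it remains open whether a different kind of group at the same place, such as an amine or a carboxylic acid, would separate from these halogens. Going by these compounds, it also remains open whether the same change would give a similar step on the core of compound 1.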